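Removing the carboxy group from compound 2

The source may hold more compounds than are shown below. What is called first, only, known or untested is meant among the compounds shown, and "the series" means these compounds.

Compound 1 (`CCCCCCCc1[nH]c2ccncc2c(=O)c1C(=O)OCC`) reads 50000 nM for solubility
Compound 2 (`CCCCCCCc1[nH]c2ccncc2c(=O)c1C(=O)O`) reads 50000 nM for solubility

Compound 2 stands level with compound 1 in a physicochemical assay for solubility, read by HPLC, at pH 7.4 (a higher number here means a more soluble compound, a lower number a less soluble compound), at the digits shown. Compound 3 (`CCCCCCCc1cc(=O)c2cnccc2[nH]1`) carries hydrogen in place of carboxy on an aromatic carbon. Within the data shown here, the one measured step (no change at the digits printed from compound 1 to compound 2 (within the scatter)) altered only the end of that group and never removed it, so it offers weak guidance. On that thin evidence, no step beyond the scatter is expected in this assay and no direction can be favoured. The expected step is a 1.3-fold lower number from compound 2 to compound 3 (0.10 log units; within the scatter) with a wide margin. For compound 3 the estimate is 40000 nM with an expected range of 12000 nM to 70000 nM overall.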

Compound 3, solubility: 50000 nM
For compound 3 the middle estimate is 1.3-fold (0.10 log units) below the measured one; measured number inside the range.
By their numbers in this assay, from the lowest: compounds 1, 2 and 3 (each within the scatter of the next).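

In this assay replacing the whole carboxy group with hydrogen gives no change at the digits printed from compound 2 to compound 3 (within the scatter) and replacing the whole ethoxycarbonyl group with hydrogen gives no change at the digits printed from compound 1 to compound 3 (within the scatter) on the same aromatic carbon. The earlier step altered only the end of this group, whereas these show that the read-out also holds when the group is gone altogether. Nothing here explains this flat result. Going by these compounds, what an amide or an amine would read on this aromatic carbon stays open, as does the effect of a shorter chain in place of the heptyl group.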